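This account rests on a few compounds, and the source may have more. Where it says the series, first, only, none or still open, it means among the compounds named here.

Measured compounds:
compound 1, `CCNS(=O)(=O)Cc1noc2ccc(Cl)cc12`: in a functional assay on the whole organism (strain STD-dd) with Mus musculus as the target, in the maximal electroshock model, with a stated time of 2 h (on this read-out higher numbers stand for an effect only at larger amounts of compound and lower numbers for an effect already at smaller amounts), compound 1 gives 21 mg/kg;
compound 2, `CC(C)NS(=O)(=O)Cc1noc2ccc(Cl)cc12`: compound 2 gives 100 mg/kg;
compound 3, `CNS(=O)(=O)Cc1noc2ccc(Br)cc12`: compound 3 gives 15 mg/kg.

Compound 1 and compound 2 share a core and differ by methyl in place of hydrogen on a saturated chain carbon bound to a saturated chain carbon and a sulfonamide nitrogen; this change made the step of a 4.8-fold higher number from compound 1 to compound 2 (0.68 log units; beyond the scatter). Compound 4, `CCNS(=O)(=O)Cc1noc2ccc(Br)cc12`, is not yet measured and differs from compound 3 by methyl in place of hydrogen on a saturated chain carbon bound to a sulfonamide nitrogen. This is the same kind of change, not the same: in compound 1 the place is on a saturated chain carbon bound to a saturated chain carbon and a sulfonamide nitrogen, in compound 3 on a saturated chain carbon bound to a sulfonamide nitrogen. The difference between the cores of compound 1 and compound 3 is not broken down here; their values lie within the scatter of each other. In this assay the step expected is a 1.7-fold higher number from compound 3 to compound 4 (0.22 log units; within the scatter), smaller than the earlier one, since that earlier step a 4.8-fold higher number from compound 1 to compound 2 (0.68 log units; beyond the scatter) came at a place already bound to a saturated chain carbon, and since compound 1 with the same ethyl group gives 21 mg/kg. For compound 4 the estimate is 25 mg/kg, between 12 mg/kg and 55 mg/kg.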

Compound 4, dose for half-maximal effect: 18 mg/kg
Estimate against measurement, compound 4: 1.4-fold (0.14 log units) above; measured number inside the range.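

In this assay, adding a methyl does not carry over from one core to another at a single size: the same change on two cores in this assay, a 4.8-fold higher number (0.68 log units; beyond the scatter) from compound 1 to compound 2 and a 1.2-fold higher number (0.08 log units; within the scatter) from compound 3 to compound 4, 4.0-fold (0.60 log units) apart, beyond the scatter of two such steps

On the bromo core, going from methylamino to ethylamino gives a 1.2-fold higher number from compound 3 to compound 4 (0.08 log units; within the scatter), and bromo in place of chloro gives a 1.2-fold lower number from compound 1 to compound 4 (0.07 log units; within the scatter). This does not show why the two methyl steps differ, since they differ in place as well as in core, and two pairs cannot separate those differences.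

Still open, going by these compounds, is what an isopropyl group on the bromo core would give, which would set the methyl at the same place on both cores. Also open, on these data alone, is how a longer chain such as butyl, or fluoro in place of bromo, would read.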